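Replacing a Nitrile: Expected Stability in Monkey Liver Microsomes

This account rests on a few compounds, and the source may have more. Where it says the series, first, only, none or still open, it means among the compounds named here.

Measured compounds:
compound 1 `Cc1ncncc1-c1nc2cc(F)c(F)cc2n1C1CC1` gives 72% in an ADME assay on microsomes from liver (Macaca fascicularis) for metabolic stability, read by LC-MS, with a stated time of 65 min, tested at 1 uM; on this read-out lower numbers stand for a less stable compound and higher numbers for a more stable compound
compound 2 `CCc1ncncc1-c1nc2cc(F)c(F)cc2n1C1CC1` gives 78% in this assay
compound 3 `N#Cc1ncncc1-c1nc2cc(F)c(F)cc2n1C1CC1` gives 85% in this assay

Compound 3 has the highest of the three numbers in this assay. Its distance from compound 1 is real, as the step of a number 13 percentage points higher from compound 1 to compound 3 (beyond the scatter) lies beyond the scatter, whereas the step of a number 7 percentage points higher from compound 2 to compound 3 (within the scatter) stays within it, so compound 2 and compound 3 cannot be told apart on these data.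

Compound 4 `Fc1cc2nc(-c3cncnc3NCCC(F)(F)F)n(C3CC3)c2cc1F` changes compound 3 in one place:
(3,3,3-trifluoropropyl)amino in place of cyano on an aromatic carbon

Both measured steps that end at compound 3 bear on this change, since each brought the cyano group in and each raised the number; the larger was beyond the scatter and modest, the smaller within it. Here the cyano group leaves again, and the entering (3,3,3-trifluoropropyl)amino group has no counterpart among the measured compounds. A modest drop in this assay is therefore expected, roughly undoing the gain seen on arrival of the cyano group. Compound 4 is estimated to give 70% in this assay, within a range of 50% to 88%. The expected step is a number 15 percentage points lower from compound 3 to compound 4 (beyond the scatter).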

Compound 4, percent of the compound remaining: 55%
Estimate against measurement, compound 4: 15 percentage points above; measured number inside the range.
By their numbers in this assay, from the lowest: compound 4; then compounds 1, 2 and 3 (each within the scatter of the next, the first and the last beyond it).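

The earlier compounds shown here carried only methyl, ethyl and cyano on this aromatic carbon next to the ring nitrogen, so they could not show how a longer chain joined through nitrogen fares here. In this assay the (3,3,3-trifluoropropyl)amino group brings a number 30 percentage points lower from compound 3 to compound 4 (beyond the scatter) and a number 23 percentage points lower from compound 2 to compound 4 (beyond the scatter) and also a number 17 percentage points lower from compound 1 to compound 4 (beyond the scatter) for the comparison with the methyl group. The drop is therefore more than the loss of the gain seen with cyano, since compound 4 also stands beyond the scatter from compound 1, which has no cyano.

No supporting measurement explains this drop. The compounds shown leave open whether a methylamino group, or a propylamino chain without fluorine, would behave the same way at this place.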